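A Urea Replaces Cyclopropyl on the Shared Core

The source may report more compounds than this note shows. Statements on the series, on what has been measured and on what is new or still open speak of the compounds shown alone.

Compound 1 `CCCNc1nc2ccc(-c3cnc(Cl)c(NS(=O)(=O)c4ccc(F)cc4)c3)cc2s1` — a functional assay on A549 cells (Homo sapiens) for antiproliferative activity, read by MTT assay, with a stated time of 72 h; a lower number here means a stronger inhibitor, a higher number a weaker inhibitor: "not determined" (no result reported)
Compound 2 `COc1ncc(-c2ccc3nc(NC4CC4)sc3c2)cc1NS(=O)(=O)c1ccc(F)cc1` — this assay: 1330 nM
Compound 3 `O=S(=O)(Nc1cc(-c2ccc3nc(NC4CC4)sc3c2)cnc1Cl)c1ccc(F)cc1` — this assay: "not determined" (no result reported)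

Compound 3 stands without a number in this assay, and compound 1 likewise has none; only compound 2 gives a result. The change from compound 3 leads to compound 4 `CCN(CC)CCNC(=O)Nc1nc2ccc(-c3cnc(Cl)c(NS(=O)(=O)c4ccc(F)cc4)c3)cc2s1`: (2-(diethylamino)ethyl)carbamoyl in place of cyclopropyl on a nitrogen on an aromatic ring. Among the compounds with values here, with no step between measured compounds to lean on, the account expects only a small shift in this assay, of no clear direction and not beyond the usual scatter, taking the single result of compound 2 as the nearest reference point. Compound 4 is therefore estimated at 1200 nM, within a range from 300 nM to 5000 nM.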

Compound 4, half-maximal inhibitory concentration: 5260 nM
For compound 4 the middle estimate is 4.4-fold (0.64 log units) below the measured one; measured number above the stated range.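

Within the data shown here, compound 3 has no single number, so no step from it to compound 4 can be read. The compounds shown leave open how replacing cyclopropyl with (2-(diethylamino)ethyl)carbamoyl alters activity. Nothing given here explains the result of compound 4.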